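The source may hold more compounds than are shown below. What is called first, only, known or untested is meant among the compounds shown, and "the series" means these compounds.

Measured so far:
compound 1, `COc1cc(C(=O)NC2CCN(C)CC2)ccc1Nc1ncc2c(n1)N(C1CCCC1)[C@@H](C)C(=O)N2C` — 8.7 nM
compound 2, `C[C@H]1C(=O)N(C)c2cnc(Nc3ccc(C(=O)NC4CCN(C)CC4)cc3OC3CCCC3)nc2N1C1CCCC1` — 127 nM

In an assay on isolated protein for inhibition of serine/threonine-protein kinase PLK1 (Homo sapiens), read by Z'-LYTE (a lower number here means a stronger inhibitor, a higher number a weaker inhibitor), compound 1 gives 8.7 nM, and compound 2 gives 127 nM; the change cyclopentyl in place of methyl on an oxygen on an aromatic ring gave a 15-fold higher number from compound 1 to compound 2 (1.16 log units; beyond the scatter). Among the measured compounds shown here, compound 2 therefore stands at the highest of the two numbers so far, with compound 1 as its only neighbour.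

Compound 3, `C[C@@H]1C(=O)N(C)c2cnc(Nc3ccc(C(=O)NC4CCN(C)CC4)cc3OC3CCCC3)nc2N1C1CCCC1`, is the next step: the two compounds have the same atoms and bonds and differ only in configuration as drawn: 1 of 1 stereo elements differ; a stereocentre at a saturated ring carbon is drawn S in compound 2 and R in compound 3. For the measured compounds named here, no measured step touches this stereocentre, so neither the pair of compound 1 and compound 2 nor anything else bears directly on it; the only step available concerns a different position. With no information on the configuration, the working expectation for this assay is no change beyond the scatter, while allowing a wide range in either direction. Compound 3 is estimated at 150 nM (range 30 nM to 2000 nM), which means an expected step of a 1.2-fold higher number from compound 2 to compound 3 (0.07 log units; within the scatter).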

Compound 3, half-maximal inhibitory concentration: 40 nM
Beside the measured number, compound 3's estimate is 3.8-fold (0.57 log units) above it, and the stated range covers the measured number.
By their numbers in this assay, from the lowest: compound 1; then compound 3; then compound 2.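

In this assay, the stereocentre at a saturated ring carbon proves to be a position that registers a change: going from S to R as drawn gives a 3.2-fold lower number from compound 2 to compound 3 (0.50 log units; beyond the scatter). Among the compounds shown here, the earlier pair spoke only to the group on the aromatic oxygen, so this is the first reading of any kind at this carbon, and it favours R with cyclopentyl on that oxygen. The step can be assigned to this stereocentre alone because of one structural fact: the fact that compounds 2 and 3 differ only in the configuration as drawn

The compounds shown leave open whether R is also favoured when the oxygen carries methyl, since the two configurations are compared only with cyclopentyl there. They also leave open how an ethyl group in place of the methyl on the stereocentre would read in this assay.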